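A few compounds are considered here, and "the series" means these few. Any claim that something is new, unique, unknown or untested is made for them only; others in the source may bear on it.

Of the compounds shown here, three built on one shared core have been tested in an assay on HEK-293T cells for antagonist activity at vitamin D3 receptor (Homo sapiens), read by a luciferase reporter, with a stated time of 24 h; a higher number here means a weaker inhibitor, a lower number a stronger inhibitor. Compound 1 `CCn1c(-c2ccc(OCc3c(-c4c(Cl)cccc4Cl)noc3C(C)C)cc2)nc2ccc(C(=O)O)cc21` carries an ethyl group on an aromatic nitrogen and in this assay gives 5760 nM. Compound 2 `CC(C)c1onc(-c2c(Cl)cccc2Cl)c1COc1ccc(-c2nc3ccc(C(=O)O)cc3n2CC(C)(C)C)cc1`, with neopentyl in that position, gives 861 nM, and the measured change is a 6.7-fold lower number from compound 1 to compound 2 (0.83 log units; beyond the scatter). Compound 3 `CC(=O)N1CCC(n2c(-c3ccc(OCc4c(-c5c(Cl)cccc5Cl)noc4C(C)C)cc3)nc3ccc(C(=O)O)cc32)CC1`, which carries 1-acetylpiperidin-4-yl on the aromatic nitrogen, gives > 10000 nM in this assay, a limit rather than a number. Compound 3 therefore stands at the limit of > 10000 nM in this assay, at which 1 of the 3 values shown sits, and no inhibition value below that limit is known for it.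

Compound 4 `CC(C)c1onc(-c2c(Cl)cccc2Cl)c1COc1ccc(-c2nc3ccc(C(=O)O)cc3n2C2CCC2)cc1` differs from compound 3 in one place: cyclobutyl in place of 1-acetylpiperidin-4-yl on an aromatic nitrogen. Within the data shown here, two measured steps bear on this change. The first is an at least 11-fold higher number from compound 2 to compound 3 (1.06 log units; beyond the scatter), and the second is an at least 1.7-fold higher number from compound 1 to compound 3 (0.23 log units; that floor lies within the scatter). Compound 4 returns to a group of carbon only, like the ethyl of compound 1 and the neopentyl of compound 2, so the step is expected to run in the opposite direction from those, toward a lower number, and to be of modest to large size. Compound 4 is therefore expected to give about 2500 nM in this assay, with a likely range from 700 nM to 9000 nM. That estimate means an expected step of an at least 4.0-fold lower number from compound 3 to compound 4 (0.60 log units; beyond the scatter).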

Compound 4, half-maximal inhibitory concentration: 1100 nM
The estimate for compound 4 lay 2.3-fold (0.36 log units) above the measured number; low and high end bracket the measured number.
By their numbers in this assay, from the lowest: compounds 2 and 4 (each within the scatter of the next); then compound 1. At a limit, above all of these: compound 3.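

Compound 3 stands at a limit, not a number: the limit of > 10000 nM in this assay, at which 1 of the 4 values shown sits. Putting cyclobutyl in place of 1-acetylpiperidin-4-yl on the aromatic nitrogen gives an at least 9.0-fold lower number from compound 3 to compound 4 (0.95 log units; beyond the scatter), so the weak result of compound 3 is not shared by a ring at this position as such, and a ring of carbon only is tolerated here. Cyclobutyl and neopentyl cannot be told apart, with a 1.3-fold higher number from compound 2 to compound 4 (0.11 log units; within the scatter), while cyclobutyl does separate from ethyl, with a 5.2-fold lower number from compound 1 to compound 4 (0.72 log units; beyond the scatter), so the gain seen earlier with neopentyl is no longer tied to that one branched chain.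

The compounds shown do not separate the acetyl group, the ring nitrogen and the six-membered ring of 1-acetylpiperidin-4-yl as the part that goes with the weak result of compound 3. They also leave open how a cyclopentyl or cyclohexyl group, a piperidine ring with a free amine, or a longer chain ending in a carboxylic acid would read on this nitrogen.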